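Removing One Chloro From a Dichlorophenyl Urea

The source may report more compounds than this note shows. Statements on the series, on what has been measured and on what is new or still open speak of the compounds shown alone.

Measured so far:
compound 1 `O=C(Nc1cccc(Cl)c1)Nc1nnc(Sc2ncnc3scc(-c4ccncc4)c23)s1` gives 21000 nM in a functional assay on HUVEC cells (Homo sapiens) for antiproliferative activity, read by MTT assay, with a stated time of 48 h; a lower number here means a stronger inhibitor, a higher number a weaker inhibitor
compound 2 `O=C(Nc1ccc(Cl)c(Cl)c1)Nc1nnc(Sc2ncnc3scc(-c4ccncc4)c23)s1` gives 7800 nM in this assay

Compound 2 has the lowest number of the two, and the step of a 2.7-fold lower number from compound 1 to compound 2 (0.43 log units; beyond the scatter) is beyond the scatter. Compound 3 `O=C(Nc1ccc(Cl)cc1)Nc1nnc(Sc2ncnc3scc(-c4ccncc4)c23)s1` differs from compound 2 by hydrogen in place of chloro on an aromatic carbon. Among the measured compounds shown here, the only measured step shows that adding a chloro to the ring lowered the number; the chloro now leaving is a different one, and nothing measured bears on it directly, so only a modest rise is expected. Compound 3 is estimated at 12000 nM (range 6000 nM to 25000 nM), a step of a 1.5-fold higher number from compound 2 to compound 3 (0.19 log units; within the scatter).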

Compound 3, half-maximal inhibitory concentration: 11600 nM
Beside the measured number, compound 3's estimate is 1.0-fold (0.01 log units) above it; low and high end bracket the measured number.
By their numbers in this assay, from the lowest: compounds 2, 3 and 1 (each within the scatter of the next, the first and the last beyond it).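

In this assay, hydrogen in place of the chloro that turns 3,4-dichlorophenyl into 4-chlorophenyl gives a 1.5-fold higher number from compound 2 to compound 3 (0.17 log units; within the scatter), so at this position the chloro cannot be told apart from hydrogen. Compound 1 and compound 3 each carry a single chloro at different places on the ring, and a 1.8-fold lower number from compound 1 to compound 3 (0.26 log units; within the scatter) shows that this move cannot be resolved either. No measurement at hand explains these numbers.

Still open, from the compounds shown here alone, is how a methoxy or trifluoromethyl group would read at this position. So is how an unsubstituted phenyl ring would compare.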